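This account rests on a few compounds, and the source may have more. Where it says the series, first, only, none or still open, it means among the compounds named here.

Series notes, cytotoxicity arm. Three compounds carry numbers in an ADME assay on MT2 cells (Homo sapiens) for cytotoxicity, read by MTT assay; a higher number here means that more compound is tolerated, a lower number that less compound is tolerated. Compound 1 `Clc1cccc(Cl)c1Cc1nnc(Nc2ccc(COCc3ccncc3)cc2)o1` gives 81000 nM. Compound 3 `OCc1ccc(Nc2ncc(Cc3c(F)cccc3F)o2)cc1Cl` gives 90000 nM, and compound 2 `Fc1cccc(F)c1Cc1cnc(Nc2ccc(Oc3ccncc3)cc2)o1` gives 21000 nM. Compound 1 therefore stands second highest of the three: its gap to compound 3 lies within the scatter, so no order between the two can be read, while compound 2 sits beyond the scatter on the lower side, tolerated at a smaller concentration than compound 1.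

Compound 4 `Clc1cccc(Cl)c1Cc1nnc(Nc2ccc(COCc3ccsc3)cc2)o1` is not yet measured in this assay . It is built from compound 1 by one change: thiophen-3-yl in place of pyridin-4-yl on a saturated chain carbon bound to an oxygen on a saturated carbon. Within the data shown here, no measured pair in the set shows this change, so nothing here tells its size. Across the three measured compounds the spread of tolerated concentrations is modest, and the change keeps one hetero atom and one acceptor in an aromatic ring of similar size. The step from compound 1 to compound 4 in this assay is expected to be small, a 1.4-fold lower number from compound 1 to compound 4 (0.13 log units; within the scatter), slightly toward a lower tolerated concentration, and possibly within the scatter. Compound 4 is estimated at 60000 nM, with a range from 25000 nM to 140000 nM.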

Compound 4, half-maximal cytotoxic concentration: > 100000 nM
Compound 4 was reported as a limit (the forecaster's own chance of this, stated with the estimate: 20%); middle value at least 1.6-fold (0.22 log units) from the limit.
By their numbers in this assay, from the lowest: compound 2; then compounds 1 and 3 (each within the scatter of the next). At a limit, above all of these: compound 4.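

In this assay compound 4 carries a limit and not a number: the limit of > 100000 nM in this assay, at which 1 of the 4 values shown sits.

Among these compounds, the first step at this position, thiophen-3-yl in place of pyridin-4-yl on a saturated chain carbon bound to an oxygen on a saturated carbon, reads as an at least 1.2-fold higher number from compound 1 to compound 4 (0.09 log units; that floor lies within the scatter). Going by these compounds, the pyridin-4-yl ring is therefore not needed here to hold the tolerated concentration of compound 1, and no fall appears with the five-membered sulfur ring, though the size of the step stays unknown past its floor.

On these data alone, what an amine, a carboxylic acid or a longer chain would do at this position remains open. As far as these compounds go, compounds 2 and 3 differ from compound 1 in more than one place, so whether the step carries over to another core also stays open.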